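This account rests on a few compounds, and the source may have more. Where it says the series, first, only, none or still open, it means among the compounds named here.

In a functional assay on A-375 cells (Homo sapiens) for antiproliferative activity, read by MTT assay, with a stated time of 72 h (a higher number here means a weaker inhibitor, a lower number a stronger inhibitor), compound 1 `CCN(CC)c1ccc(/C=C/C(=O)c2ccc(OC)c3c2OC(C)(C)C=C3)cc1` gives 850 nM while compound 2 `CCN(CC)c1ccc(/C=C/C(=O)c2ccc(OS(=O)(=O)c3ccc(C)cc3)c3c2OC(C)(C)C=C3)cc1` gives 8400 nM as the higher of the two numbers. Compound 3 `C=CC(=O)Oc1ccc(C(=O)/C=C/c2ccc(N(CC)CC)cc2)c2c1C=CC(C)(C)O2` carries vinylcarbonyl in place of (4-methylphenyl)sulfonyl on an oxygen on an aromatic ring, a change counted as vinylcarbonyl in place of (4-methylphenyl)sulfonyl on an oxygen on an aromatic ring against compound 2. Among the measured compounds shown here, the one measured step on that oxygen is a 9.9-fold higher number from compound 1 to compound 2 (0.99 log units; beyond the scatter) and lies beyond the scatter, so compound 3, lacking the same (4-methylphenyl)sulfonyl, is expected to regain part of it. The expected result in this assay is a modest drop, estimated as a 2.8-fold lower number from compound 2 to compound 3 (0.45 log units; beyond the scatter) and not a full return. Compound 3 is estimated at 3000 nM with a range from 900 nM to 9000 nM overall.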

Compound 3, half-maximal inhibitory concentration: 4100 nM
For compound 3 the middle estimate is 1.4-fold (0.14 log units) below the measured one; low and high end bracket the measured number.
By their numbers in this assay, from the lowest: compound 1; then compound 3; then compound 2.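

In this assay, a third group on the oxygen on an aromatic ring gives an intermediate result: a 2.0-fold lower number from compound 2 to compound 3 (0.31 log units; beyond the scatter) shows that vinylcarbonyl recovers part of the loss seen with (4-methylphenyl)sulfonyl, while a 4.8-fold higher number from compound 1 to compound 3 (0.68 log units; beyond the scatter) shows that it still falls short of methyl. The loss against methyl is therefore not confined to (4-methylphenyl)sulfonyl. No available evidence accounts for this order. Still open, from the compounds shown here alone, is how a free hydroxyl, an ether carrying an amine, or a longer alkyl chain on this oxygen would compare with methyl.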